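Three Measured Permeabilities and One Expected Value

This account rests on a few compounds, and the source may have more. Where it says the series, first, only, none or still open, it means among the compounds named here.

Compound 1: `FC(F)(F)c1ccc(-c2ccc3c(NCCCNCc4ccco4)ccnc3c2)cc1`, 237 10^-6 cm/s
Compound 2: `COc1cccc(CNCCCNc2ccnc3cc(-c4ccc(C(C)(C)C)cc4)ccc23)c1O`, 237 10^-6 cm/s
Compound 3: `FC(F)(F)c1cc(-c2ccc3c(NCCCNCc4ccco4)ccnc3c2)cc(C(F)(F)F)c1`, 237 10^-6 cm/s

All three were run in an ADME assay for permeability, using PAMPA, with a stated time of 30 min, at pH 7.4; a lower number here means that the compound crosses the layer more slowly, a higher number that the compound crosses the layer faster. In this assay compound 1 gives 237 10^-6 cm/s, compound 2 gives 237 10^-6 cm/s, and compound 3 gives 237 10^-6 cm/s. Compound 1 therefore stands level with compound 2 and with compound 3 at the digits shown; its nearest neighbour is compound 2 and its furthest is compound 3, and in both cases the two values show no change beyond the usual scatter. For the measured compounds named here, no two of the measured compounds differ in only one place, so no measured single step is available to guide the next change.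

Compound 4, `COc1ccccc1Oc1ccc2c(NCCCNCc3ccco3)ccnc2c1`, has not yet been measured in this assay. It differs from compound 1 in one place: 2-methoxyphenoxy in place of 4-(trifluoromethyl)phenyl on an aromatic carbon. With no measured step to lean on, the expectation rests on the three values already in hand, which sit together at the digits shown. Compound 4 is expected to give 230 10^-6 cm/s, with a range from 150 10^-6 cm/s to 240 10^-6 cm/s. The step of a 1.0-fold lower number from compound 1 to compound 4 (0.01 log units; within the scatter) is thus expected to be none beyond the scatter.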

Compound 4, apparent permeability: 317 10^-6 cm/s
For compound 4 the middle estimate is 1.4-fold (0.14 log units) below the measured one, outside the stated range (above it).
By their numbers in this assay, from the lowest: compounds 1, 2, 3 and 4 (each within the scatter of the next).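

In this assay, for the compounds shown here, the only measured single step at this aromatic carbon is a 1.3-fold higher number from compound 1 to compound 4 (0.13 log units; within the scatter), with 2-methoxyphenoxy in place of 4-(trifluoromethyl)phenyl. The earlier compounds shown here offered no such pair, and this one shows that the position can take a group with 2 hydrogen-bond acceptors, in place of one with 0, and with oxygen in place of fluorine, without a step beyond the scatter. The exchange also puts a phenoxy group where a phenyl group stood, yet a single pair cannot separate that difference from the change of substituents on the ring, and no measurement shown gives a cause for the step.

The compounds shown leave open whether a group of a different kind at this position, such as a primary amine, a carboxylic acid or a morpholine ring, would also give a step within the scatter in this assay. They also leave open whether the exchange of 4-(trifluoromethyl)phenyl for 2-methoxyphenoxy would give a step of like size if the amine chain of compound 1 were replaced by a longer chain.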